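Arylidene oxindoles: nitro to chloro on the pendant ring

A few compounds are considered here, and "the series" means these few. Any claim that something is new, unique, unknown or untested is made for them only; others in the source may bear on it.

Measured compounds:
compound 1, `O=C1/C(=C\c2ccc(O)cc2)c2ccccc2N1c1c(Cl)cccc1Cl` — a functional assay on MOLT-4 cells (Homo sapiens) for cytotoxicity, read by MTT assay, with a stated time of 72 h; a higher number here means that more compound is needed for the effect, a lower number that less compound is needed: "not determined" (no result reported)
compound 2, `O=C1/C(=C\c2ccccc2[N+](=O)[O-])c2ccccc2N1c1c(Cl)cccc1Cl` — this assay: 6 ug/mL

Compound 2 holds the only number shown for this assay; compound 1 stands beside it without a single value, so there is no measured step to set against any structural change. Compound 3, `O=C1/C(=C\c2ccccc2Cl)c2ccccc2N1c1c(Cl)cccc1Cl`, is the next member of the series and has not yet been measured. It differs from compound 2 in one place: chloro in place of nitro on an aromatic carbon.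

Among the compounds with values here, no measured pair bounds this kind of change, so the expected step of a 1.3-fold higher number from compound 2 to compound 3 (0.12 log units; within the scatter) is given no direction, only a size that is expected to stay within the usual scatter of repeated measurements; a shift in either direction is equally plausible on the evidence at hand. On that basis compound 3 is estimated at 8 ug/mL, with a range from 3 ug/mL to 20 ug/mL.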

Compound 3, concentration for half-maximal effect: 7 ug/mL
For compound 3 the middle estimate is 1.1-fold (0.06 log units) above the measured one, within the range that was stated.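

In this assay, within the data shown here, replacing nitro with chloro on an aromatic carbon, ortho to a large group, gives a 1.2-fold higher number from compound 2 to compound 3 (0.07 log units; within the scatter), the only measured step so far. At this position, then, the 2-nitrophenyl and 2-chlorophenyl compounds cannot be told apart, even though nitro carries hydrogen-bond acceptors and a double bond outside aromatic rings and chloro has neither. No measurement at hand speaks to the reason for this result.

Going by these compounds, the step covers a single exchange at a single position, so it remains open whether an amine or a carboxylic acid in the same place would also stay within the scatter of compound 2 and compound 3. With compound 1 at "not determined" (no result reported) in this assay, the compounds shown also leave open whether moving a group elsewhere on the pendant ring would change the read-out at all, and whether chloro and nitro would remain indistinguishable there.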